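The source may report more compounds than this note shows. Statements on the series, on what has been measured and on what is new or still open speak of the compounds shown alone.

Compound 3 `CCC(=O)Nc1ccc(-c2nc3cc(C(F)(F)F)ccc3n2C)cc1` gives 8000 nM in an ADME assay on MT4 cells (Homo sapiens) for cytotoxicity, read by MTT assay, with a stated time of 96 h (on this read-out lower numbers stand for higher toxicity in this test and higher numbers for lower toxicity in this test), the lowest of the three numbers in hand; compound 2 `Cn1c(-c2ccc(NC(=O)CN3CCCC3)cc2)nc2cc(C(F)(F)F)ccc21` gives 16000 nM and compound 1 `CN1CCN(CC(=O)Nc2ccc(-c3nc4cc(C(F)(F)F)ccc4n3C)cc2)CC1` gives 22000 nM. Compound 4 `Cn1c(-c2ccc(NC(=O)CN3CCN(c4ccccc4)CC3)cc2)nc2cc(C(F)(F)F)ccc21` differs from compound 3 by 4-phenylpiperazin-1-yl in place of methyl on a saturated chain carbon bound to a carbonyl carbon. Going by the values given here, two measured steps bear on this change, both run in the reverse direction: a 2.8-fold lower number from compound 1 to compound 3 (0.44 log units; beyond the scatter), which lies beyond the scatter, and a 2.0-fold lower number from compound 2 to compound 3 (0.30 log units; within the scatter), which lies within it. Returning an amine to that chain carbon is therefore expected to move the number upward by a modest amount at most, so compound 4 is expected to show a 1.9-fold higher number from compound 3 to compound 4 (0.27 log units; within the scatter). The estimate for compound 4 in this assay is 15000 nM, with a range from 6000 nM to 40000 nM.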

Compound 4, half-maximal cytotoxic concentration: 1500 nM
Beside the measured number, compound 4's estimate is 10-fold (1.00 log units) above it; the whole stated range lies above it.
By their numbers in this assay, from the lowest: compound 4; then compounds 3, 2 and 1 (each within the scatter of the next, the first and the last beyond it).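

In this assay, going by these compounds alone, the earlier steps at the saturated chain carbon bound to a carbonyl carbon were modest at most, but 4-phenylpiperazin-1-yl there gives a 5.3-fold lower number from compound 3 to compound 4 (0.73 log units; beyond the scatter) and an 11-fold lower number from compound 2 to compound 4 (1.03 log units; beyond the scatter). Phenyl in place of methyl on an amine nitrogen in a ring gives a 15-fold lower number from compound 1 to compound 4 (1.17 log units; beyond the scatter), so a piperazine alone does not bring the low number; the phenyl on it goes with the drop. The compounds shown leave open whether a benzyl, a pyridine ring or a fluorophenyl on that nitrogen would behave like phenyl. Nothing available here accounts for the drop.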